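Chloromethylbenzyl purines: second chloro on the core

A few compounds are considered here, and "the series" means these few. Any claim that something is new, unique, unknown or untested is made for them only; others in the source may bear on it.

Measured so far:
- compound 1 `ClCc1cccc(Cn2cnc3ncnc(Cl)c32)c1`: 39800 nM
- compound 2 `ClCc1ccc(Cn2cnc3nc(Cl)nc(Cl)c32)cc1`: 5750 nM
- compound 3 `ClCc1ccc(Cn2cnc3c(Cl)nc(Cl)nc32)cc1`: 50100 nM

All three numbers come from a functional assay on MDA-MB-435 cells (Homo sapiens) for cytotoxicity, read by sulforhodamine B assay, with a stated time of 48 h; a higher number here means that more compound is tolerated, a lower number that less compound is tolerated. Compound 1 stands second highest of the three. Its nearest neighbour is compound 3, whose number is within the scatter of that of compound 1, so no order between these two can be read. Compound 2 gives a clearly lower number than compound 1, beyond the scatter, but compound 2 differs from compound 1 in more than one place, so no single change can be held to account for that gap.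

Compound 4 `ClCc1cccc(Cn2cnc3nc(Cl)nc(Cl)c32)c1` is not yet measured. It differs from compound 1 in one place: chloro in place of hydrogen on an aromatic carbon. Going by the values given here, no pair of measured compounds shows this single change, so the size of the step in this assay is open. The lower number of compound 2, which also carries two chloro groups on the core, is the only pointer, and it is confounded by the different benzyl pattern.

Compound 4 is expected to give an estimate of 15000 nM in this assay, within the range 5000 nM to 45000 nM. This expected step, a 2.7-fold lower number from compound 1 to compound 4 (0.42 log units; beyond the scatter), is a moderate drop in the number, set between the values of compound 1 and compound 2, with wide uncertainty.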

Compound 4, concentration lethal to 50% of the cells: 5240 nM
The estimate for compound 4 lay 2.9-fold (0.46 log units) above the measured number, within the range that was stated.
By their numbers in this assay, from the lowest: compounds 4 and 2 (each within the scatter of the next); then compounds 1 and 3 (each within the scatter of the next).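

In this assay, going by these compounds alone, chloro in place of hydrogen on the aromatic carbon between two ring nitrogen atoms gives a 7.6-fold lower number from compound 1 to compound 4 (0.88 log units; beyond the scatter), the first step that rests on a single change. The second chloro on the core can therefore be read at this position on its own, with the benzyl pattern of compound 1 kept, whereas compound 2 could offer only a pointer confounded by its different benzyl pattern. Compound 4 (5240 nM) and compound 2 (5750 nM) now stand within the scatter of each other, and nothing at hand gives a measured reason for the step.

Whether the step is particular to chloro remains open, since the compounds shown carry only hydrogen or chloro on this carbon, and an amine, a methoxy group or a bromo group there could give a step of a different size. Also open is whether the same change would give a step of similar size on the benzyl pattern of compound 2, where the compound carrying hydrogen on this carbon is absent from those shown.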